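This account rests on a few compounds, and the source may have more. Where it says the series, first, only, none or still open, it means among the compounds named here.

Working notes on the series. In an ADME assay on microsomes from liver (Rattus norvegicus) for metabolic stability, read by LC-MS, using NADPH, with stated times of 5 min and 60 min, tested at 4 uM (on this read-out higher numbers stand for a more stable compound and lower numbers for a less stable compound), compound 1 `CC1=C(c2nc(-c3ccc(C#N)cc3)cs2)C(c2ccc(Cl)nc2)NC(=O)N1` gives 63.4% and compound 2 `CC1=C(c2nc(-c3ccc(C#N)cc3)cs2)C(c2cccc(O)c2)NC(=O)N1` gives 52.4%, which makes compound 2 the lower of the two measured compounds. Compound 3 `COc1ccc(C2NC(=O)NC(C)=C2c2nc(-c3ccc(C#N)cc3)cs2)cc1` keeps the core of compound 2 and has 4-methoxyphenyl in place of 3-hydroxyphenyl on a saturated ring carbon. Within the data shown here, one measured step bears on this change, as it alters the same ring carbon: a number 11 percentage points lower from compound 1 to compound 2 (beyond the scatter). Among the measured compounds shown here, that step is modest and involves a different pair of groups, and no measured step leads from 3-hydroxyphenyl to 4-methoxyphenyl. It therefore gives no firm direction, and no step beyond the scatter is expected in this assay. The expected step is a number 2.4 percentage points lower from compound 2 to compound 3 (within the scatter). Compound 3 is estimated at 50%, with an expected range of 30% to 68%.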

Compound 3, percent of the compound remaining: 63.2%
The estimate for compound 3 lay 13.2 percentage points below the measured number; the measured number falls inside the stated range.
By their numbers in this assay, from the lowest: compound 2; then compounds 3 and 1 (each within the scatter of the next).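

In this assay, the saturated ring carbon responds to the swap of 3-hydroxyphenyl for 4-methoxyphenyl (a number 10.8 percentage points higher from compound 2 to compound 3 (beyond the scatter)), and this change takes the group from 1 hydrogen-bond donor to 0. The pair 4-methoxyphenyl and 6-chloropyridin-3-yl is not separated (a number 0.2 percentage points lower from compound 1 to compound 3 (within the scatter)), so among these three groups only 3-hydroxyphenyl stands apart, with steps beyond the scatter to both others. Nothing at hand gives a measured reason for the step.

The hydroxyl-to-methoxy change and the shift of ring position come together in this pair, so a 4-hydroxyphenyl or 3-methoxyphenyl group on this carbon would be needed to tell them apart. From the compounds shown here alone, how a non-aromatic group at this carbon, such as a cyclohexyl ring or a short alkyl chain, would read also remains open.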